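Removing One Double Bond from the Tail of Compound 3

The compounds below may be only part of what the source reports. "The series", "measured", "known", "first", "only" and "open" are said of these compounds alone.

Measured so far:
compound 1 `Cc1cccc(C(=O)NCCC2CCN(S(=O)(=O)NC(=O)NC[C@@H]3C[C@@H]4C=C[C@@H]3C4)CC2)n1` gives 20%
compound 2 `O=C(NC1CCCCC1)NS(=O)(=O)N1CCC(CCNC(=O)c2ccnc3ccccc23)CC1` gives 16%
compound 3 `COc1ncccc1C(=O)NCCC1CCN(S(=O)(=O)NC(=O)NC[C@H]2C[C@@H]3C=C[C@@H]2C3)CC1` gives 20%

In a functional assay on the whole organism (blood) with Rattus norvegicus as the target, with stated times of 24 h and 1 h, at a dose of 5 mg/kg by the intraperitoneal route (on this read-out higher numbers stand for a stronger effect at the one dose given and lower numbers for a weaker effect), compound 3 stands level with compound 1 at the digits shown, and those two numbers are together the highest of the three; the gap to compound 2 lies within the scatter, so no order among the three can be read from these values.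

Compound 4 `COc1ncccc1C(=O)NCCC1CCN(S(=O)(=O)NC(=O)NC[C@@H]2C[C@@H]3CC[C@@H]2C3)CC1` differs from compound 3 in one place: a group of 7 heavy atoms (7 carbon; 2 five-membered non-aromatic rings of carbon only) in place of a group of 7 heavy atoms (7 carbon; 2 five-membered non-aromatic rings of carbon only), on a saturated chain carbon bound to an amide-type nitrogen. For the measured compounds named here, no pair of measured compounds shows what such a change does here, so the expected step is a number 1 percentage points lower from compound 3 to compound 4 (within the scatter), none beyond the scatter. Compound 4 is therefore estimated at 19%, within a range of 8% to 30%.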

Compound 4, a percentage reported as activity, at one dose (the size of the read-out at that dose, not a potency): 35%
Estimate against measurement, compound 4: 16 percentage points below; the measured number lies above the stated range.
By their numbers in this assay, from the lowest: compounds 2, 1 and 3 (each within the scatter of the next); then compound 4.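

In this assay, this is the first step among the compounds shown that lies beyond the scatter: removing the 1 double bond from the group on a saturated chain carbon bound to an amide-type nitrogen gives a number 15 percentage points higher from compound 3 to compound 4 (beyond the scatter). The carbon count and the two five-membered rings stay the same, so this position responds to a small change in the group. No measured evidence explains the gain.

As far as these compounds go, whether the same removal would raise compound 1 remains open, as does the effect of a hydroxyl group or a longer chain at this position.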